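A Benzyl Group Replaces the Methylated Aryl Ring

The source may hold more compounds than are shown below. What is called first, only, known or untested is meant among the compounds shown, and "the series" means these compounds.

Measured compounds:
compound 1, `Clc1cccc(-n2ncnc2Nc2ccccc2)c1Cl`: 3890 nM
compound 2, `Cc1ccccc1Nc1ncnn1-c1cccc(Cl)c1Cl`: 240 nM

Both compounds were tested in a functional assay for antagonist activity at P2X purinoceptor 7 (Rattus norvegicus), read by FLIPR and calcium flux; a lower number here means a stronger inhibitor, a higher number a weaker inhibitor. Compound 2 stands at the lower of the two numbers, and the step of a 16-fold lower number from compound 1 to compound 2 (1.21 log units; beyond the scatter) separates it from compound 1. Compound 3, `Clc1cccc(-n2ncnc2NCc2ccccc2)c1Cl`, is not yet measured. It differs from compound 2 by benzyl in place of 2-methylphenyl on a nitrogen on an aromatic ring.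

Among the measured compounds shown here, only one measured step bears on this change. The step of a 16-fold lower number from compound 1 to compound 2 (1.21 log units; beyond the scatter) shows that the methyl on the aromatic carbon, present in compound 2 and absent in compound 1, went with a large drop in the number. For the measured compounds named here, compound 3 also lacks that methyl on the ring, carrying its carbon instead in the benzyl link, and no measured pair shows what a benzyl in place of an aryl group on that nitrogen does. The expectation for compound 3 is therefore a step back toward the number of compound 1, estimated as a 13-fold higher number from compound 2 to compound 3 (1.10 log units; beyond the scatter) in this assay, with wide uncertainty. Compound 3 is estimated at 3000 nM, within 700 nM to 13000 nM.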

Compound 3, half-maximal inhibitory concentration: 209 nM
Compound 3: the middle estimate sits 14-fold (1.16 log units) above what was measured; measured number below the stated range.
By their numbers in this assay, from the lowest: compounds 3 and 2 (each within the scatter of the next); then compound 1.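

In this assay, exchanging 2-methylphenyl for benzyl on the nitrogen gives a 1.1-fold lower number from compound 2 to compound 3 (0.06 log units; within the scatter) and so leaves the two groups indistinguishable, although each has one six-membered aromatic ring of carbon only and they are joined differently. Measured against the plain phenyl of compound 1, benzyl gives a 19-fold lower number from compound 1 to compound 3 (1.27 log units; beyond the scatter) and so stands alongside the earlier step, a 16-fold lower number from compound 1 to compound 2 (1.21 log units; beyond the scatter), as a large one. The gain seen earlier therefore does not depend on a methyl on the aromatic ring, since compound 3 has none and still sits with compound 2, though no measurement at hand explains why the two groups match.

The compounds shown leave open whether a longer chain, such as 2-phenylethyl, would hold this level on the same nitrogen, and whether a methyl added to the ring of the benzyl group would lower the number further, as it did on phenyl. They also leave open how an amine or a carboxylic acid on that ring would read in this assay.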